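This account rests on a few compounds, and the source may have more. Where it says the series, first, only, none or still open, it means among the compounds named here.

Among the compounds with values here, in a functional assay on HeLa cells (Homo sapiens) for antiproliferative activity, read by MTT assay, with a stated time of 48 h (on this read-out lower numbers stand for stronger inhibition and higher numbers for weaker inhibition), three compounds built on a shared core have numbers so far. Compound 1 `COc1ccc(N(C)c2ccnc(Cl)n2)cc1Cl` gives 517 nM, compound 2 `COc1ccc(N(C)c2ccnc(Cl)n2)cc1O` gives 96 nM, and compound 3 `COc1ccc(N(C)c2ccnc(Cl)n2)cc1OCCBr` gives 3310 nM. Compound 3 therefore has the highest number of the three and is the weakest inhibitor in this small set.

Compound 4 `COc1ccc(N(C)c2ccnc(Cl)n2)cc1OCCCBr` is the next to be read. Its structure differs from that of compound 3 as follows: bromomethyl in place of bromo on a saturated chain carbon, two bonds along the chain from an oxygen on an aromatic ring. In other words, 3-bromopropoxy takes the place of 2-bromoethoxy.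

Two measured steps lead to the 2-bromoethoxy group: the large 34-fold higher number from compound 2 to compound 3 (1.54 log units; beyond the scatter) and the modest 6.4-fold higher number from compound 1 to compound 3 (0.81 log units; beyond the scatter). The remaining step, a 5.4-fold lower number from compound 1 to compound 2 (0.73 log units; beyond the scatter), does not involve the chain at all. Both steps to compound 3 install the chain in place of another group, and neither lengthens it, so the data hold no direct measure of what a longer chain does. The size of those steps shows only that this site can move the number considerably.

With nothing pointing either way, the expected outcome is no step beyond the scatter, with a 1.3-fold lower number from compound 3 to compound 4 (0.12 log units; within the scatter) as the estimated change. For compound 4 the expected value is 2500 nM, with an estimated range from 700 nM to 8000 nM.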

Compound 4, half-maximal inhibitory concentration: 307 nM
Compound 4: middle estimate off by 8.1-fold (0.91 log units), on the high side; measured number outside the range, below it.
By their numbers in this assay, from the lowest: compound 2; then compounds 4 and 1 (each within the scatter of the next); then compound 3.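

In this assay, within the data shown here, lengthening 2-bromoethoxy to 3-bromopropoxy gives an 11-fold lower number from compound 3 to compound 4 (1.03 log units; beyond the scatter) and is the first direct measure of chain length at this position, showing that this small change alone can move the number substantially. The longer chain does not match the hydroxy group of compound 2, with a 3.2-fold higher number from compound 2 to compound 4 (0.50 log units; beyond the scatter) marking a modest step beyond the scatter, whereas a 1.7-fold lower number from compound 1 to compound 4 (0.23 log units; within the scatter) lies within the scatter, so 3-bromopropoxy and chloro cannot be told apart here. No evidence is available on what lies behind the large step from the shorter bromo chain to the longer one.

Among these compounds, with only two chain lengths in hand, it remains open whether a longer bromoalkoxy chain such as 4-bromobutoxy would continue this direction, level off or reverse it. On these data alone, it is also open how much the bromine itself contributes, which a plain propoxy group or a 3-aminopropoxy group in place of 3-bromopropoxy would help to separate from the contribution of the chain.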